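The compounds below may be only part of what the source reports. "The series", "measured", "known", "first", "only" and "open" are said of these compounds alone.

Measured so far:
compound 1, `CCCCCCCCC(=O)NCc1ccc(O)c(OC)c1I`: 3380 nM
compound 2, `CCCCCCCCC(=O)NCc1cc(OC)c(O)cc1Br`: 16.1 nM
compound 3, `CCCCCCCCC(=O)NCc1cc(Cl)c(O)c(OC)c1`: 631 nM

In an assay on HEK293 cells for inhibition of transient receptor potential cation channel subfamily V member 1 (Homo sapiens) (on this read-out lower numbers stand for stronger inhibition and higher numbers for weaker inhibition), compound 3 stands second highest of these three numbers. Compound 1 gives the nearest and higher number, compound 2 the furthest and much lower one. Compound 4, `CCCCCCCCC(=O)NCc1cc(OC)c(O)c(C(C)=O)c1`, has not been measured. It differs from compound 3 by one change: acetyl in place of chloro on an aromatic carbon. Within the data shown here, no step between two measured compounds shows how this exchange plays out, so the expectation rests on compound 3 alone. A shift of modest size toward a higher number, not certainly beyond the scatter, is expected, as a 1.4-fold higher number from compound 3 to compound 4 (0.15 log units; within the scatter) states. Compound 4 is therefore estimated at 900 nM, within a range from 200 nM to 4000 nM.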

Compound 4, half-maximal inhibitory concentration: 10400 nM
For compound 4 the middle estimate is 12-fold (1.06 log units) below the measured one, and the stated range ends below it.
By their numbers in this assay, from the lowest: compound 2; then compound 3; then compound 1; then compound 4.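

In this assay, acetyl in place of chloro on this aromatic carbon, ortho to a hydroxy group, gives a 16-fold higher number from compound 3 to compound 4 (1.22 log units; beyond the scatter). The exchange therefore goes with much weaker inhibition, showing that the group at this one position can strongly change the result. No measurement here accounts for the size of this step.

Acetyl differs from chloro in both heavy atoms and hydrogen-bond acceptors, and a single step cannot separate the two. From the compounds shown here alone, how a methyl group or an amine at this position would compare with chloro and acetyl remains open.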